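Aryl amine swap at the fused core of compound 1

The source may report more compounds than this note shows. Statements on the series, on what has been measured and on what is new or still open speak of the compounds shown alone.

Compound 1 `CN(C[C@H]1Cc2c(cccc2N2C[C@@H]3C[C@H]2CN3)CN1)[C@H]1CCCc2cccnc21` gives 146 nM.
Compound 2 `CN(C[C@@H]1Cc2c(cccc2N2CCNCC2)CN1)[C@H]1CCCc2cccnc21` gives 313 nM.
Compound 3 `Cc1cnc2c(c1)CCC[C@@H]2N(C)C[C@H]1Cc2c(cccc2N2CCNCC2)CN1` gives 16.1 nM.

The read-out throughout is a functional assay on CCRF-CEM cells for antagonist activity at C-X-C chemokine receptor type 4 (Homo sapiens), read by calcium flux, with stated times of 25 min and 90 s; on this read-out lower numbers stand for stronger inhibition and higher numbers for weaker inhibition. Among the three measured compounds, compound 1 stands second highest: compound 2 sits beyond the scatter above it, and compound 3 sits well beyond the scatter below it, so compound 1 is neither the strongest nor the weakest of the set.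

Compound 4 `CN1CCN(c2cccc3c2C[C@H](CN(C)[C@H]2CCCc4cccnc42)NC3)CC1` has not been measured. Relative to compound 1 the change is a group of 7 heavy atoms (5 carbon, 2 nitrogen; one six-membered non-aromatic ring with 2 hetero atoms) in place of a group of 7 heavy atoms (5 carbon, 2 nitrogen; 2 five-membered non-aromatic rings with 1 hetero atom each), on an aromatic carbon. Within the data shown here, no step between measured compounds isolates this change; compounds 2 and 3 differ from compound 4 in more than one place, so their values only frame the plausible range rather than fix it.

Because compound 1 sits at 146 nM and the incoming group removes the hydrogen-bond donor counted above while keeping the same number of heavy atoms and acceptors, the expectation is a modest loss, a step from compound 1 to compound 4 of about a 2.1-fold higher number from compound 1 to compound 4 (0.31 log units; beyond the scatter), not far beyond the scatter. Compound 4 is accordingly estimated at 300 nM, expected to fall between 100 nM and 1000 nM.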

Compound 4, half-maximal inhibitory concentration: 29.6 nM
The estimate for compound 4 lay 10-fold (1.01 log units) above the measured number; measured number below the stated range.
By their numbers in this assay, from the lowest: compounds 3 and 4 (each within the scatter of the next); then compound 1; then compound 2.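

In this assay, replacing the bridged bicyclic amine of compound 1 with 4-methylpiperazin-1-yl gives a 4.9-fold lower number from compound 1 to compound 4 (0.69 log units; beyond the scatter), a step beyond the scatter, on the aromatic carbon that is ortho to a fused ring and meta to a fused ring. Among these compounds, this is the first direct reading at this position, and it shows that the group there affects inhibition even when the heavy-atom count and the atom make-up stay the same, and that a group with no hydrogen-bond donor can give the lower number on this core. Nothing available accounts for the direction of this step.

The step changes the ring system, the hydrogen-bond donor and the methyl on nitrogen together, and no pair of compounds shown separates these contributions. As far as these compounds go, it also remains open how this position would respond to other groups, such as morpholin-4-yl, 4-ethylpiperazin-1-yl or an open-chain dimethylamino group, and whether the same step would hold on a core carrying a different substituent elsewhere.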